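The compounds below may be only part of what the source reports. "The series", "measured", "known", "first", "only" and "open" are said of these compounds alone.

Of the compounds shown here, three have been measured in a functional assay on HCT-116 cells (Homo sapiens) for antiproliferative activity, read by sulforhodamine B assay, with a stated time of 72 h; on this read-out higher numbers stand for weaker inhibition and lower numbers for stronger inhibition. Compound 1 `Cn1ncc(Cl)c1-c1cc(C(=O)N[C@@H]2CN[C@H](CCO)C[C@H]2c2ccc(F)c(F)c2)oc1Cl` gives 360 nM, compound 2 `Cn1ncc(Cl)c1-c1cc(C(=O)N[C@@H]2CN[C@H](CCN3CCCCC3)C[C@H]2c2ccc(Cl)c(Cl)c2)oc1Cl` gives 1020 nM, and compound 3 `O=C(N[C@@H]1CNCC[C@H]1c1ccc(Cl)cc1)c1ccc(-c2ncnc3c2CCC3O)s1` gives 23000 nM. Among these three numbers compound 2 stands second highest: compound 1 sits nearer to it, with a lower number beyond the usual scatter, while compound 3 lies furthest away, with a higher number also beyond the scatter. Compound 1 and compound 2 differ from each other in more than one place, so their two values are simply noted side by side.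

The next compound, compound 4 `COCC[C@@H]1C[C@@H](c2ccc(Cl)c(Cl)c2)[C@H](NC(=O)c2cc(-c3c(Cl)cnn3C)c(Cl)o2)CN1`, differs from compound 2 in a single place: methoxy in place of piperidin-1-yl on a saturated chain carbon, two bonds along the chain from a saturated ring carbon. Among the measured compounds shown here, no measured pair in the set isolates this change, so the direction has to be judged from the spread of the values alone. The step from compound 2 to compound 4 is expected to be modest, a 1.5-fold lower number from compound 2 to compound 4 (0.16 log units; within the scatter), leaning toward a somewhat lower number rather than a higher one, though a result within the scatter of compound 2 would not surprise. On that basis compound 4 is estimated to give 700 nM in this assay, with a plausible range from 250 nM to 2000 nM.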

Compound 4, half-maximal inhibitory concentration: 470 nM
Beside the measured number, compound 4's estimate is 1.5-fold (0.17 log units) above it; the measured number falls inside the stated range.
By their numbers in this assay, from the lowest: compounds 1 and 4 (each within the scatter of the next); then compound 2; then compound 3.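

In this assay, among the compounds shown here, the exchange of 2-(piperidin-1-yl)ethyl for 2-methoxyethyl gives the first single-place step, a 2.2-fold lower number from compound 2 to compound 4 (0.34 log units; beyond the scatter), a modest move that lies beyond the scatter. It shows that at this saturated chain carbon, two bonds along the chain from a saturated ring carbon, piperidin-1-yl can give way to methoxy without a rise in the number: 6 heavy atoms leave, 2 enter, the ring is gone and the count of 1 hydrogen-bond acceptor stays the same. Nothing on hand accounts for the direction or size of this step.

With only this one exchange at the position, the compounds shown cannot separate the loss of the ring from the replacement of its nitrogen by the oxygen of methoxy, and an open-chain amine such as dimethylamino or a ring such as morpholin-4-yl on the same chain would bear on that. On these data alone, whether the trend continues with a longer alkoxy chain, or turns with a carboxylic acid at this place, also remains open.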